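From trifluoromethyl to trifluoromethoxy: a small expected step

The source may report more compounds than this note shows. Statements on the series, on what has been measured and on what is new or still open speak of the compounds shown alone.

Measured in a functional assay on A2780 cells (Homo sapiens) for inhibition, with a stated time of 72 h; a higher number here means a weaker inhibitor, a lower number a stronger inhibitor:
- Compound 1 `CN1c2ccc(NC(=S)Nc3ccc([N+](=O)[O-])cc3)cc2C(C)(C)C(=O)C1(C)C`: 4400 nM
- Compound 2 `CN1c2ccc(NC(=S)Nc3ccc(C(F)(F)F)cc3)cc2C(C)(C)C(=O)C1(C)C`: 3900 nM

Among the compounds with values here, compound 2 stands level with compound 1, the only other compound measured, since their two values lie within the scatter of each other. Compound 3 `CN1c2ccc(NC(=S)Nc3ccc(OC(F)(F)F)cc3)cc2C(C)(C)C(=O)C1(C)C` keeps the shared core but carries trifluoromethoxy in place of trifluoromethyl on an aromatic carbon. Within the data shown here, the one measured step that bears on this change, trifluoromethyl in place of nitro on an aromatic carbon, gave a 1.1-fold lower number from compound 1 to compound 2 (0.05 log units; within the scatter). A single small step is thin evidence, but no change beyond the scatter is expected in this assay. The estimated step is a 1.0-fold lower number from compound 2 to compound 3 (0.01 log units; within the scatter). Compound 3 is expected at 3800 nM, with an estimated range from 1900 nM to 7500 nM.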

Compound 3, half-maximal inhibitory concentration: 5400 nM
The estimate for compound 3 lay 1.4-fold (0.15 log units) below the measured number; low and high end bracket the measured number.
By their numbers in this assay, from the lowest: compounds 2, 1 and 3 (each within the scatter of the next).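

Trifluoromethoxy in place of trifluoromethyl, on an aromatic carbon para to a large group, gives a 1.4-fold higher number from compound 2 to compound 3 (0.14 log units; within the scatter) in this assay. Trifluoromethoxy in place of nitro gives a 1.2-fold higher number from compound 1 to compound 3 (0.09 log units; within the scatter), so all three groups tried at this position now stand within the scatter of each other, and adding an oxygen to the group does not shift the number beyond it. No measurement is available that could explain this result. From the compounds shown here alone, whether an amine, a carboxylic acid or a longer chain at this position would move the number beyond the scatter remains open.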